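The source may report more compounds than this note shows. Statements on the series, on what has been measured and on what is new or still open speak of the compounds shown alone.

Measured compounds and their values:

compound 1, `Nc1scc(CN2CCN(c3cc(Cl)cc(Cl)c3)CC2)c1C(=O)c1ccc(Cl)cc1`: 1%
compound 2, `Nc1scc(CN2CCN(c3ccccc3C(F)(F)F)CC2)c1C(=O)c1ccc(Cl)cc1`: 0%
compound 3, `Nc1scc(CN2CCN(c3ccncc3)CC2)c1C(=O)c1ccc(Cl)cc1`: 1%

In an assay on CHO cells for displacement of a labelled ligand from adenosine receptor A1 (Homo sapiens), read by scintillation counting, with a stated time of 120 min, tested at 10 uM (on this read-out lower numbers stand for less inhibition and higher numbers for more inhibition at the one concentration tested (going by the name of the read-out)), compound 3 gives 1%, which is level with compound 1 at the digits shown, the step being no change at the digits printed from compound 1 to compound 3 (within the scatter). Its furthest neighbour is compound 2, with a number 1 percentage points higher from compound 2 to compound 3 (within the scatter). All three measured compounds therefore sit together at the bottom of the read-out, and none of them is separated from another by more than the scatter.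

Compound 4, `Nc1scc(CN2CCN(c3ccc(F)c(Cl)c3)CC2)c1C(=O)c1ccc(Cl)cc1`, has not yet been measured. It differs from compound 3 in one place: 3-chloro-4-fluorophenyl in place of pyridin-4-yl on an amine nitrogen in a ring. The three measured steps all concern the same position, the group on an amine nitrogen in a ring, and each of them was within the scatter: a number 1 percentage points lower from compound 1 to compound 2 (within the scatter), no change at the digits printed from compound 1 to compound 3 (within the scatter) and a number 1 percentage points higher from compound 2 to compound 3 (within the scatter). Three different groups at that position left the read-out unchanged, so the exchange of pyridin-4-yl for 3-chloro-4-fluorophenyl is expected to do the same, with no step beyond the scatter in either direction. Compound 4 is estimated to give 1%, between 0% and 10%, which means an expected step of no change at the digits printed from compound 3 to compound 4 (within the scatter).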

Compound 4, a percentage reported as inhibition, at one concentration (the size of the read-out at that concentration, not a potency): 0%
Estimate against measurement, compound 4: 1 percentage points above; the measured number falls inside the stated range.
By their numbers in this assay, from the lowest: compounds 2, 4, 1 and 3 (each within the scatter of the next).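

In this assay the series now holds a fourth group on the amine nitrogen in a ring, and 3-chloro-4-fluorophenyl stands apart from none of the others, with a number 1 percentage points lower from compound 3 to compound 4 (within the scatter) and no change at the digits printed from compound 2 to compound 4 (within the scatter) and also a number 1 percentage points lower from compound 1 to compound 4 (within the scatter) across the three single-place exchanges. What this adds is that a six-membered aromatic ring of carbon only, carrying fluorine and chlorine and with no hydrogen-bond acceptor, leaves the read-out where pyridin-4-yl left it, so neither the loss of the ring nitrogen nor the larger group separates these compounds, and all four remain at the bottom of the read-out, where differences between groups at this position cannot be resolved. No supporting measurement bears on why this position gives so flat a result.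

The compounds shown leave open whether anything other than an aromatic ring at this position, such as a carboxylic acid on a longer chain or a simple primary amine on an alkyl chain, would lift the read-out at all. They also leave open whether a change elsewhere on the shared core would do so, since every exchange here falls at the one position.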